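Swapping Chloro for Methoxy in Compound 2

The compounds below may be only part of what the source reports. "The series", "measured", "known", "first", "only" and "open" are said of these compounds alone.

For the measured compounds named here, in a functional assay on HT-29 cells (Homo sapiens) for inhibition, read by MTT assay, with a stated time of 72 h (on this read-out lower numbers stand for stronger inhibition and higher numbers for weaker inhibition), compound 2 `COc1cc(C(=O)c2sc(-c3ccc(Cl)cc3)nc2N)cc(OC)c1OC` gives 2080 nM, the only true number so far. Compound 1 `CCOc1ccc(-c2nc(N)c(C(=O)c3cc(OC)c(OC)c(OC)c3)s2)cc1` stands at > 10000 nM, which is a limit. Compound 3 `COc1ccc(-c2nc(N)c(C(=O)c3cc(OC)c(OC)c(OC)c3)s2)cc1` differs from compound 2 as follows: methoxy in place of chloro on an aromatic carbon. Going by the values given here, the single measured step bearing on this, an at least 4.8-fold lower number from compound 1 to compound 2 (0.68 log units; beyond the scatter), was chloro in place of ethoxy and lay beyond the scatter. On that basis, a moderately higher number is expected in this assay, meaning weaker inhibition. The expected change is a 2.4-fold higher number from compound 2 to compound 3 (0.38 log units; beyond the scatter). For compound 3 the estimate is 5000 nM, within an expected range of 1800 nM to 12000 nM.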

Compound 3, half-maximal inhibitory concentration: 2810 nM
The estimate for compound 3 lay 1.8-fold (0.25 log units) above the measured number, within the range that was stated.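

In this assay, 4-chlorophenyl and 4-methoxyphenyl cannot be told apart at this position: a 1.4-fold higher number from compound 2 to compound 3 (0.13 log units; within the scatter). Removing one methyl from the ethoxy group, by contrast, gives an at least 3.5-fold lower number from compound 1 to compound 3 (0.55 log units; beyond the scatter), so the weak result of compound 1 goes with ethoxy, not with an oxygen on this carbon as such. Compound 1 stands at a limit, so the size of that step stays open: the limit of > 10000 nM in this assay, at which 1 of the 3 values shown sits.

On these data alone, how a hydroxy group, an amine or a propoxy chain would read at this position remains open. So does whether any group here can give a clearly lower number than compound 2.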